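Trifluoromethyl step in a cytotoxicity series

The compounds below may be only part of what the source reports. "The series", "measured", "known", "first", "only" and "open" are said of these compounds alone.

Measured compounds:
compound 1 `N=C(N)c1ccc(-c2ccc(-c3ccc(C(=N)N)cc3)cc2)cc1`: 22100 nM
compound 2 `N=C(NO)c1ccc(-c2ccc(-c3ccc(/C(N)=N\O)cc3)cc2)cc1`: > 211000 nM (a limit of the assay)
compound 3 `N=C(NO)c1ccc(-c2ccc(-c3ccc(/C(N)=N\O)cc3)cc2C(F)(F)F)cc1`: 13300000 nM

In a functional assay on L6 cells (Rattus norvegicus) for cytotoxicity (on this read-out lower numbers stand for stronger inhibition and higher numbers for weaker inhibition), compound 1 gives 22100 nM. Compound 2 reaches only a limit of the assay, > 211000 nM, noted as the limit of > 211000 nM in this assay, at which 1 of the 3 values shown sits. Compound 3 gives 13300000 nM in this assay, a much higher number than compound 1. The difference between the cores of compound 1 and compound 2 is not broken down here. From compound 2 to compound 3 the change is trifluoromethyl in place of hydrogen on an aromatic carbon; its step, a step that the limit leaves unreadable from compound 2 to compound 3, cannot be read from the limit. Compound 4 `N=C(N)c1ccc(-c2ccc(-c3ccc(C(=N)N)cc3)c(C(F)(F)F)c2)cc1` is not yet measured; it carries the same kind of change from compound 1, (trifluoromethyl in place of hydrogen on an aromatic carbon), the place here given as ortho and meta to a group of 9 heavy atoms rather than to a large group. The measured step being unreadable, the expectation for compound 4 rests on compound 1 at 22100 nM alone. Compound 4 is expected at 45000 nM in this assay, between 10000 nM and 200000 nM, an expected step of a 2.0-fold higher number from compound 1 to compound 4 (0.31 log units; beyond the scatter).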

Compound 4, half-maximal inhibitory concentration: 9400 nM
The estimate for compound 4 lay 4.8-fold (0.68 log units) above the measured number, and the stated range ends above it.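

In this assay, trifluoromethyl in place of hydrogen on an aromatic carbon of the core of compound 1 gives a 2.4-fold lower number from compound 1 to compound 4 (0.37 log units; beyond the scatter). The step for the same kind of change on the core of compound 2 cannot be read, so this single readable step does not show whether the change carries from one core to the other, in size or in direction. Compound 2 stands at a limit of the assay: the limit of > 211000 nM in this assay, at which 1 of the 4 values shown sits.

The compounds shown leave open how an amine or a carboxylic acid in place of that hydrogen on the core of compound 1 would compare in this assay. They also leave open whether trifluoromethyl gives a readable step of similar size on any other core.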